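This account rests on a few compounds, and the source may have more. Where it says the series, first, only, none or still open, it means among the compounds named here.

Compound 1 `Cc1ccc2nc(NC(=O)c3cn(-c4ccccc4)nc3-c3ccccc3)sc2c1`, compound 2 `O=C(Nc1nc2ccc(F)cc2s1)c1cn(-c2ccccc2)nc1-c1ccc(F)cc1`, compound 3 `COc1ccc2nc(NC(=O)c3cn(-c4ccccc4)nc3-c3ccc(F)cc3)sc2c1` and the not yet measured compound 4 `Cc1ccc2nc(NC(=O)c3cn(-c4ccccc4)nc3-c3ccc(F)cc3)sc2c1` share one core. In a functional assay on HT-29 cells (Homo sapiens) for cytotoxicity, read by MTT assay, with a stated time of 72 h (a higher number here means a weaker inhibitor, a lower number a stronger inhibitor), compound 2 gives 4160 nM and compound 3 gives 33200 nM. Compound 1 reaches only > 50000 nM, which is a limit of the assay and not a number (the limit of > 50000 nM in this assay, at which 1 of the 3 values shown sits). Compound 3 thus stands at the highest of the two numbers shown. The change from compound 3 to compound 4 is methyl in place of methoxy on an aromatic carbon. Going by the values given here, no measured step covers this exchange; the only measured step, an 8.0-fold higher number from compound 2 to compound 3 (0.90 log units; beyond the scatter), replaces a different group and so bears on it only loosely. A step of uncertain direction, roughly within the scatter, is expected, a 1.1-fold lower number from compound 3 to compound 4 (0.04 log units; within the scatter). Compound 4 is therefore estimated at 30000 nM, between 8000 nM and 150000 nM.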

Compound 4, half-maximal inhibitory concentration: 22900 nM
Compound 4: the middle estimate sits 1.3-fold (0.12 log units) above what was measured, and the stated range covers the measured number.
By their numbers in this assay, from the lowest: compound 2; then compounds 4 and 3 (each within the scatter of the next). At a limit, above all of these: compound 1.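

Methyl and methoxy at this position are not told apart, as methyl in place of methoxy gives a 1.4-fold lower number from compound 3 to compound 4 (0.16 log units; within the scatter). Fluoro at the same position stands apart from methyl as well as from methoxy, with methyl in place of fluoro giving a 5.5-fold higher number from compound 2 to compound 4 (0.74 log units; beyond the scatter). Fluoro in place of hydrogen at another aromatic carbon gives an at least 2.1-fold lower number from compound 1 to compound 4 (0.33 log units; beyond the scatter), a step that starts from a limit of compound 1 and not from a number: the limit of > 50000 nM in this assay, at which 1 of the 4 values shown sits.

As far as these compounds go, how an amine or a carboxylic acid at this position would read in this assay remains open. So does the effect of a longer chain there, such as ethyl.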